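The compounds below may be only part of what the source reports. "The series", "measured", "known", "first", "only" and "open" are said of these compounds alone.

Measured in a functional assay on OVCAR-5 cells (Homo sapiens) for inhibition, with a stated time of 48 h; on this read-out lower numbers stand for stronger inhibition of growth and higher numbers for weaker inhibition of growth:
- compound 1 `COc1ccccc1/C=C/C(=O)c1c(O)cc2occc2c1OC`: > 100000 nM (a limit of the assay, not a number)
- compound 2 `COc1c(C(=O)/C=C/c2ccc(Cl)cc2)c(O)c(Br)c2occc12`: 6040 nM
- compound 3 `C=CCc1c(O)c(C(=O)/C=C/c2ccccc2)c(OC)c2ccoc12`: 3220 nM

Compound 1 gives only a limit (> 100000 nM) and offers no number for comparison. That leaves two numbers in the series. Compound 3 at 3220 nM and compound 2 at 6040 nM lie within the scatter of each other.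

The next compound is compound 4 `C=CCc1c(O)c(C(=O)/C=C/c2ccc(Cl)cc2)c(OC)c2ccoc12`, which differs from compound 3 by chloro in place of hydrogen on an aromatic carbon, para to a large group, turning phenyl to 4-chlorophenyl (chloro in place of hydrogen on an aromatic carbon). Among the compounds with values here, no measured pair isolates this change. Within the data shown here, the only guide is compound 2, which also carries 4-chlorophenyl and gives 6040 nM, within the scatter of compound 3. No step beyond the scatter is therefore expected in this assay, and the direction is left open. The expected 1.2-fold lower number from compound 3 to compound 4 (0.06 log units; within the scatter) is small. For compound 4 the estimated value is 2800 nM, with an expected range of 1000 nM to 8000 nM.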

Compound 4, concentration for 50% growth inhibition: 2800 nM
For compound 4 middle estimate and measured number coincide at the digits printed; the measured number falls inside the stated range.
By their numbers in this assay, from the lowest: compounds 4, 3 and 2 (each within the scatter of the next, the first and the last beyond it). At a limit, above all of these: compound 1.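

In this assay the change from phenyl to 4-chlorophenyl now has a matched reading, and it stays within the scatter (a 1.2-fold lower number from compound 3 to compound 4 (0.06 log units; within the scatter)). Within the data shown here, with 4-chlorophenyl common to both compounds, allyl in place of bromo on an aromatic carbon gives the first step beyond the scatter, a modest one (a 2.2-fold lower number from compound 2 to compound 4 (0.33 log units; beyond the scatter)). Nothing in the data at hand bears on the cause of either step.

Only hydrogen and chloro are shown at this position on the phenyl ring, so a methoxy group or an amine there remains an open case. On these data alone, it also remains open whether a propyl group or a longer chain in place of allyl would hold the step from the bromo compound.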